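The source may report more compounds than this note shows. Statements on the series, on what has been measured and on what is new or still open speak of the compounds shown alone.

Measured in a functional assay on A2780 cells (Homo sapiens) for inhibition, read by sulforhodamine B assay; on this read-out lower numbers stand for stronger inhibition of growth and higher numbers for weaker inhibition of growth:

- compound 1 `Oc1cccc2[nH]c(-c3ccc(-c4ccc(-c5ccc(F)cc5)cc4)cc3)nc12`: 41200 nM
- compound 2 `Oc1ccc(-c2ccc(-c3ccc(-c4nc5c(O)cccc5[nH]4)cc3)cc2)cc1`: 2920 nM
- compound 3 `COc1ccc(-c2ccc(-c3ccc(-c4nc5c(O)cccc5[nH]4)cc3)cc2)cc1`: 8640 nM

Compound 3, at 8640 nM, stands in the middle of these three numbers. Its nearest neighbour is compound 2, with a 3.0-fold higher number from compound 2 to compound 3 (0.47 log units; beyond the scatter).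

Compound 4 `Oc1cccc2[nH]c(-c3ccc(-c4ccc(-c5cccc(Cl)c5)cc4)cc3)nc12` differs from compound 3 in one place: 3-chlorophenyl in place of 4-methoxyphenyl on an aromatic carbon. The most relevant measured step is a 4.8-fold lower number from compound 1 to compound 3 (0.68 log units; beyond the scatter), where methoxy replaces fluoro. The step of a 14-fold lower number from compound 1 to compound 2 (1.15 log units; beyond the scatter) points the same way, with hydroxy replacing fluoro. Within the data shown here, compound 1, the only halogen-bearing compound measured, has the highest number, 41200 nM. Replacing methoxy with a halogen might therefore reverse that gain. However, no measured compound carries chloro or has a substituent at this position, so the guide is loose.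

A modest rise is expected, and the estimated step is a 2.9-fold higher number from compound 3 to compound 4 (0.46 log units; beyond the scatter). The estimate for compound 4 is 25000 nM, with an expected range of 9000 nM to 70000 nM.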

Compound 4, concentration for 50% growth inhibition: 2800 nM
Estimate against measurement, compound 4: 8.9-fold (0.95 log units) above, and the stated range ends above it.
By their numbers in this assay, from the lowest: compounds 4 and 2 (each within the scatter of the next); then compound 3; then compound 1.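

In this assay the swap of 4-methoxyphenyl for 3-chlorophenyl gives a 3.1-fold lower number from compound 3 to compound 4 (0.49 log units; beyond the scatter) and the swap of 4-fluorophenyl for 3-chlorophenyl gives a 15-fold lower number from compound 1 to compound 4 (1.17 log units; beyond the scatter) so a halogen on this ring does not by itself go with weak inhibition of growth. The step to 3-chlorophenyl from 4-hydroxyphenyl, a 1.0-fold lower number from compound 2 to compound 4 (0.02 log units; within the scatter) shows that a ring with no hydrogen-bond donors can sit at the same level as compound 2, so the hydroxy group is not required for that level. Compound 1 and compound 4 differ in both the halogen and where it sits, so their large step cannot be credited to either change alone.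

Still open, as far as these compounds go, is whether 4-chlorophenyl or 3-fluorophenyl would separate those two changes, and how a ring carrying an amine or a carboxylic acid would behave. Nothing available on these compounds gives a reason for any of these steps.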